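The source may report more compounds than this note shows. Statements on the series, on what has been measured and on what is new or still open speak of the compounds shown alone.

The study sets three measured compounds beside one that still awaits measurement. Compound 1 `COc1ccc2[nH]c(-c3ccccc3)c(C3=C(Br)C(=O)NC3=O)c2c1` gives 2.48 in a physicochemical assay for lipophilicity; on this read-out higher numbers stand for higher lipophilicity and lower numbers for lower lipophilicity. Compound 2 `CCCOc1ccc2[nH]c(-c3ccccc3)c(C3=C(Br)C(=O)NC3=O)c2c1` gives 3.16 in this assay. The change between them, (ethyl in place of hydrogen on a saturated chain carbon bound to an oxygen on an aromatic ring), brought a number 0.68 log units higher from compound 1 to compound 2 (beyond the scatter). Compound 3 `CCc1ccc2[nH]c(-c3cccc(OC)c3)c(C3=C(Br)C(=O)NC3=O)c2c1` gives 3.35 in this assay; its number and that of compound 2 lie within the scatter of each other, while the number of compound 1 sits lower, beyond the scatter. The difference between the core of compound 1 and the core of compound 3 is not broken down here. Compound 4 `CCCCc1ccc2[nH]c(-c3cccc(OC)c3)c(C3=C(Br)C(=O)NC3=O)c2c1` is still to be measured in this assay. It differs from compound 3 by ethyl in place of hydrogen on a saturated chain carbon, two bonds along the chain from an aromatic carbon. For the measured compounds named here, this is the same kind of change as the one from compound 1 to compound 2, though the place differs: there the saturated chain carbon is bound to an oxygen on an aromatic ring, here it stands two bonds along the chain from an aromatic carbon. The step of a number 0.70 log units higher from compound 3 to compound 4 (beyond the scatter) is expected, because the earlier change gave a number 0.68 log units higher from compound 1 to compound 2 (beyond the scatter). Compound 4 is therefore estimated at 4.05, expected to fall between 3.7 and 4.4.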

Compound 4, partition coefficient: 3.81
For compound 4 the middle estimate is 0.24 log units above the measured one; low and high end bracket the measured number.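

In this assay, ethyl in place of hydrogen on a saturated chain carbon, two bonds along the chain from an aromatic carbon, gave a number 0.46 log units higher from compound 3 to compound 4 (beyond the scatter), which runs in the same direction as a number 0.68 log units higher from compound 1 to compound 2 (beyond the scatter), where the same kind of change stood on a saturated chain carbon bound to an oxygen on an aromatic ring. The direction of the change therefore carried from one core to the other, with both steps beyond the scatter, but these two pairs differ in the place of the change as well as in the core, and they do not show that the step keeps a fixed size or that it would hold on any further core. Nothing at hand bears on what lies behind the size of either step.

The compounds shown leave open whether a longer chain such as hexyl would extend the rise seen with butyl. They also leave open how an amine or a carboxylic acid at the end of that chain would read in this assay.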